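From 2-chloropyridin-3-yl to 2-chlorophenyl: compound 4

The source may report more compounds than this note shows. Statements on the series, on what has been measured and on what is new or still open speak of the compounds shown alone.

Values so far in an ADME assay on HepG2 cells (Homo sapiens) for cytotoxicity, read by resazurin assay, with a stated time of 48 h (a lower number here means that less compound is needed, a higher number that more compound is needed for the effect), as follows
Compound 1 `Cc1nc(C)c(C(=O)Nc2ccc(F)c(-c3nc4ncc(-c5cccnc5Cl)cn4n3)c2)o1` gives > 50000 nM as a limit
Compound 2 `O=C(Nc1ccc(F)c(-c2nc3ncc(-c4ccc(F)cc4)cc3[nH]2)c1)N1CCCC1` gives > 50000 nM as a limit
Compound 3 `O=C(Nc1ccc(F)c(-c2nc3ncc(-c4ccc(F)nc4)cc3[nH]2)c1)N1CCCC1` gives > 50000 nM as a limit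

In this assay compound 1 stands at > 50000 nM as a limit and not as a number. The whole set shares this position, with the limit of > 50000 nM in this assay, at which 3 of the 3 values shown sit, as the common reading. Compound 4 `Cc1nc(C)c(C(=O)Nc2ccc(F)c(-c3nc4ncc(-c5ccccc5Cl)cn4n3)c2)o1` comes from compound 1 by 2-chlorophenyl in place of 2-chloropyridin-3-yl on an aromatic carbon in one place, 2-chlorophenyl in place of 2-chloropyridin-3-yl on an aromatic carbon. Going by the values given here, the one measured step that bears on this is a step that the two limits leave unreadable from compound 2 to compound 3 where 6-fluoropyridin-3-yl takes the place of 4-fluorophenyl on an aromatic carbon, the same kinds of ring exchanged in the other direction. Its size cannot be read, so no measured size carries over. Since compound 1 gives > 50000 nM as a limit, no step beyond the usual scatter is expected in this assay in either direction, and a limit is the likely report for compound 4. The estimated change is a step that the limit leaves unreadable from compound 1 to compound 4 on this reading. For compound 4 the estimated value is 60000 nM with an expected range from 30000 nM to 120000 nM in this assay.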

Compound 4, half-maximal effective concentration in the HepG2 assay: > 50000 nM
Compound 4 was reported as a limit (the forecaster's own chance of this, stated with the estimate: 85%); the middle value is on the limit's open side.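

In the HepG2 assay compound 1 gives > 50000 nM, which is a limit. In the HepG2 assay compound 4 gives > 50000 nM, which is also a limit. Going by these compounds alone, no step between these two compounds can be read: the limit of > 50000 nM in the HepG2 assay, at which 4 of the 4 values shown sit.

The compounds shown leave open how far any of them lies past that limit, and so whether 2-chlorophenyl in place of 2-chloropyridin-3-yl changes this read-out at all.

In a physicochemical assay for solubility, read by LC-MS, in phosphate buffer, at pH 6.5, tested at 50 uM (a lower number here means a less soluble compound, a higher number a more soluble compound), compound 1 gives 2590 nM and compound 4 gives 2400 nM, two values within the usual scatter of each other.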